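The compounds below may be only part of what the source reports. "The series", "measured", "known", "first", "only" and "open" are said of these compounds alone.

Measured so far in a physicochemical assay for solubility, read by HPLC; a lower number here means a less soluble compound, a higher number a more soluble compound: compound 1 `COc1ccc(NC[C@H](O)COc2ccc(N3C[C@H](CNC(C)=O)OC3=O)cc2F)cc1` gives 56000 nM; compound 2 `CC(=O)NC[C@H]1CN(c2ccc(OC[C@@H](O)CNc3ccc(C#N)cc3)c(F)c2)C(=O)O1` gives 47000 nM; compound 3 `CC(=O)NC[C@H]1CN(c2ccc(OC[C@H](O)CNc3ccc(C#N)cc3)c(F)c2)C(=O)O1` gives 69000 nM.

Compound 2 holds the lowest of the three numbers, but neither gap reaches past the scatter: a 1.2-fold lower number from compound 1 to compound 2 (0.08 log units; within the scatter), and a 1.5-fold higher number from compound 2 to compound 3 (0.17 log units; within the scatter). The second of these pairs rests only on drawn configuration the fact that compounds 2 and 3 differ only in the configuration as drawn and so tells nothing about the aryl group on the amine nitrogen.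

Compound 4 `CC(=O)NC[C@H]1CN(c2ccc(OC[C@@H](O)CNc3cccnc3)c(F)c2)C(=O)O1` differs from compound 2 in one place: pyridin-3-yl in place of 4-cyanophenyl on an amine nitrogen. Among the measured compounds shown here, the only measured step touching that part of the molecule, a 1.2-fold lower number from compound 1 to compound 2 (0.08 log units; within the scatter), swapped one substituent on the aromatic ring for another and left the number within the scatter. For the measured compounds named here, the present change is larger, replacing the whole ring, and no measured pair covers it; the working expectation in this assay is therefore no step beyond the scatter, in either direction. Compound 4 is expected to give 60000 nM, with a range from 30000 nM to 120000 nM. The expected step is a 1.3-fold higher number from compound 2 to compound 4 (0.11 log units; within the scatter).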

Compound 4, solubility: 3040000 nM
Compound 4: the middle estimate sits 51-fold (1.70 log units) below what was measured; the whole stated range lies below it.
By their numbers in this assay, from the lowest: compounds 2, 1 and 3 (each within the scatter of the next); then compound 4.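

In this assay, exchanging the aryl group on the amine nitrogen moves the number far beyond the scatter from either earlier aryl group (a 65-fold higher number from compound 2 to compound 4 (1.81 log units; beyond the scatter); a 54-fold higher number from compound 1 to compound 4 (1.73 log units; beyond the scatter)). The substituent swap on the earlier ring stayed within the scatter (a 1.2-fold lower number from compound 1 to compound 2 (0.08 log units; within the scatter)), so at this position replacing the whole ring with pyridin-3-yl has an effect on the number that exchanging one substituent did not. No measured property among the data bears on why the number rises this far.

The compounds shown do not separate the ring nitrogen of pyridin-3-yl from the absence of a ring substituent; a plain phenyl, pyridin-2-yl or pyridin-4-yl on the same amine nitrogen would separate them. Also open, going by these compounds, is whether the step holds in the drawn configuration of compound 3.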